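The compounds below may be only part of what the source reports. "The series", "measured", "known", "first", "only" and "open" are said of these compounds alone.

Measured so far in a physicochemical assay for lipophilicity, measured as octanol-water partition; on this read-out lower numbers stand for lower lipophilicity and higher numbers for higher lipophilicity
compound 1 `O=C(NNc1ccnc2cc(Cl)ccc12)c1ccccc1/N=C/c1ccc(F)cc1` reads 5.18
compound 2 `O=C(NNc1ccnc2cc(Cl)ccc12)c1ccccc1/N=C/c1ccc(Cl)cc1` reads 5.62
compound 3 `O=C(NNc1ccnc2cc(Cl)ccc12)c1ccccc1/N=C/c1ccc([N+](=O)[O-])cc1` reads 4.58

Compound 3 stands lowest of the three, with compound 1 nearest and compound 2 furthest. Next comes compound 4 `N#Cc1ccc(/C=N/c2ccccc2C(=O)NNc2ccnc3cc(Cl)ccc23)cc1` which differs from compound 3 by cyano in place of nitro on an aromatic carbon in one change, cyano in place of nitro on an aromatic carbon. Within the data shown here, no measured compound carries the cyano group, so only the steps at this same place bear on it. These are the modest a number 0.44 log units higher from compound 1 to compound 2 (beyond the scatter) and the modest a number 0.60 log units lower from compound 1 to compound 3 (beyond the scatter) and the large a number 1.04 log units lower from compound 2 to compound 3 (beyond the scatter) and they show that swaps here can move the number. None of them fixes a direction for this swap, so no step beyond the scatter is expected, with a slight lean lower. The expected change is a number 0.08 log units lower from compound 3 to compound 4 (within the scatter) as an estimate only. In this assay compound 4 is expected near 4.5 and the estimated range runs from 4.1 up to 4.9 for now.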

Compound 4, partition coefficient: 4.83
For compound 4 the middle estimate is 0.33 log units below the measured one, and the stated range covers the measured number.
By their numbers in this assay, from the lowest: compounds 3 and 4 (each within the scatter of the next); then compound 1; then compound 2.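

In this assay the change from 4-nitrophenyl to 4-cyanophenyl gives a number 0.25 log units higher from compound 3 to compound 4 (within the scatter), so cyano and nitro cannot be told apart at this position on the shared core. Cyano nevertheless separates from both halogens, with a number 0.79 log units lower from compound 2 to compound 4 (beyond the scatter) and a number 0.35 log units lower from compound 1 to compound 4 (beyond the scatter), which places compound 3 and compound 4 together below compound 1 and compound 2 in these four compounds. No available evidence accounts for this grouping.

Going by these compounds, how an amine or a carboxylic acid on this aromatic carbon would read remains open, as does the reading of a longer chain such as butyl. On these data alone, whether the same grouping of cyano, nitro and the halogens would hold on a different core also remains open.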